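Removing the chloro from compound 3: expected loss of affinity

The compounds below may be only part of what the source reports. "The series", "measured", "known", "first", "only" and "open" are said of these compounds alone.

Compound 3 `CN1[C@H](COc2cncc(Cl)c2)C[C@H]2C[C@H]21` gives 0.37 nM in an assay on CHO-K1 cells for displacement of a labelled ligand from Neuronal acetylcholine receptor; alpha4/beta2 (Homo sapiens), read by scintillation counting (on this read-out higher numbers stand for weaker inhibition and lower numbers for stronger inhibition), the lowest of the three numbers; compound 1 `CN1[C@H](COc2cccnc2F)C[C@H]2C[C@H]21` gives 31.9 nM and compound 2 `Cc1ncccc1OC[C@@H]1C[C@H]2C[C@H]2N1C` gives 231 nM. For the measured compounds named here, the only measured step, a 7.2-fold higher number from compound 1 to compound 2 (0.86 log units; beyond the scatter), concerns a different exchange at a different place, so no measured pair covers removal of a halogen. Compound 4 `CN1[C@H](COc2cccnc2)C[C@H]2C[C@H]21` differs from compound 3 by hydrogen in place of chloro on an aromatic carbon. Going by the values given here, with no matching step, the expectation rests on compound 3 standing far lower than compounds 1 and 2, which both lack a chloro; losing it is expected to raise the number beyond the scatter. The expected step is an 8.1-fold higher number from compound 3 to compound 4 (0.91 log units; beyond the scatter). Compound 4 is therefore estimated at 3 nM, within 0.8 nM to 12 nM.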

Compound 4, inhibition constant: 5.5 nM
For compound 4 the middle estimate is 1.8-fold (0.26 log units) below the measured one; low and high end bracket the measured number.
By their numbers in this assay, from the lowest: compound 3; then compound 4; then compound 1; then compound 2.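

The chloro on the aromatic carbon two atoms from the ring nitrogen carries much of the affinity, with a 15-fold higher number from compound 3 to compound 4 (1.17 log units; beyond the scatter) on its loss. Hydrogen also compares favourably with the other two groups on their own carbon: a 42-fold lower number from compound 2 to compound 4 (1.62 log units; beyond the scatter) and a 5.8-fold lower number from compound 1 to compound 4 (0.76 log units; beyond the scatter) show methyl and fluoro lowering affinity there, the opposite of what chloro does at its carbon. No measurement at hand explains these steps.

Open, going by these compounds, is whether bromo, methoxy or nitrile on the chloro carbon would hold the affinity. Also open, on these data alone, is whether fluoro or methyl would lower it at that carbon too.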